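Three Limits and a Fourth Compound Still to Be Measured

The source may hold more compounds than are shown below. What is called first, only, known or untested is meant among the compounds shown, and "the series" means these compounds.

Compound 1 `CCCCCCCCCCCSC(=S)C1=C(Nc2ccc(Cl)cc2)CC(C)(C)CC1=O` is the reference. In a functional assay on PBMC cells (Homo sapiens) for inhibition, read by ELISA, with a stated time of 18 h (a higher number here means a weaker inhibitor, a lower number a stronger inhibitor), compound 1 gives > 20 ug/mL, which is a limit of the assay. Compound 2 `CC1(C)CC(=O)C(C(=S)SCc2ccccc2)=C(Nc2ccc(Cl)cc2)C1` carries phenyl in place of decyl on a saturated chain carbon bound to a sulfur. In this assay compound 2 gives > 20 ug/mL, again a limit. Compound 3 `CCCCCCCCCCCSC(=S)C1=C(Nc2ccc(Br)cc2)CC(C)(C)CC1=O` differs from compound 1 by bromo in place of chloro on an aromatic carbon. In this assay compound 3 gives > 20 ug/mL, also a limit. The steps a step that the two limits leave unreadable from compound 1 to compound 2 and a step that the two limits leave unreadable from compound 1 to compound 3 cannot be sized, since (the limit of > 20 ug/mL in this assay, at which 3 of the 3 values shown sit). Compound 4 `CC1(C)CC(=O)C(C(=S)SCc2ccccc2)=C(Nc2ccc(Br)cc2)C1` is not yet measured; it differs from compound 3 by phenyl in place of decyl on a saturated chain carbon bound to a sulfur, the same change as that from compound 1 to compound 2, made at the same place. The step that the limit leaves unreadable from compound 3 to compound 4 is expected to be small, resting on compound 1 and compound 2 both sitting at the limit (the limit of > 20 ug/mL in this assay, at which 3 of the 3 values shown sit). Compound 4 is thus estimated to give 30 ug/mL in this assay, likely between 15 ug/mL and 80 ug/mL, most probably reported only as a limit.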

Compound 4, half-maximal inhibitory concentration: > 20 ug/mL
Compound 4: no number, only a limit; the forecaster's own chance of this, stated with the estimate: 85%; the middle value lies beyond the limit too.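

In this assay compound 4 gives > 20 ug/mL, a limit of the assay. No step to compound 4 from compound 2 or compound 3 can be read: the limit of > 20 ug/mL in this assay, at which 4 of the 4 values shown sit.

The four compounds leave open how strong an inhibitor any of them is in this assay, and whether either exchange changes that strength.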